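This account rests on a few compounds, and the source may have more. Where it says the series, first, only, none or still open, it means among the compounds named here.

Measured compounds:
compound 1, `Cc1cccc2c1CC/C2=C\C(=O)NC1CC1`: 7%
compound 2, `O=C(/C=C1\CCc2cc(Cl)ccc21)NC1CC1`: 29%
compound 3, `CNC(=O)/C=C1\CCc2ccc(F)cc21`: 38%

In a functional assay on the whole organism with Rattus norvegicus as the target, at a dose of 20 mg/kg by the oral route (on this read-out higher numbers stand for more inhibition at the one dose given (going by the name of the read-out) and lower numbers for less inhibition), compound 1 gives 7%, the lowest of the three numbers. Its nearest neighbour is compound 2, which in this assay gives 29%, a number higher by more than the usual scatter; furthest from it is compound 3, which in this assay gives 38%, also higher by more than the scatter. No two of these three compounds differ in one place only, so the three numbers stand side by side without any single change being attributable to a step.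

Compound 4, `Cc1cccc2c1CC/C2=C\C(N)=O`, has not been measured. It differs from compound 1 in one place: hydrogen in place of cyclopropyl on an amide-type nitrogen. Among the measured compounds shown here, nothing among the measured compounds isolates this change, since compound 2 and compound 3 carry other differences as well. The expectation is therefore built only on compound 1 itself: compound 4 is estimated to stay close to it, with a step of a number 5 percentage points higher from compound 1 to compound 4 (within the scatter) that is expected to lie within the usual scatter, leaning if anything slightly upward. Compound 4 is expected to give about 12%, within a range from 0% to 35%.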

Compound 4, a percentage reported as inhibition, in the whole organism at one dose (the size of the read-out at that dose, not a potency): 13%
For compound 4 the middle estimate is 1 percentage points below the measured one; the measured number falls inside the stated range.
By their numbers in this assay, from the lowest: compounds 1 and 4 (each within the scatter of the next); then compounds 2 and 3 (each within the scatter of the next).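

In this assay, replacing the cyclopropyl on the amide-type nitrogen with hydrogen gives a number 6 percentage points higher from compound 1 to compound 4 (within the scatter), the only comparison among the compounds shown in which a single place changes. On the core of compound 1, the cyclopropyl is therefore not required for the small inhibition seen at this dose, since compound 4, which has only hydrogen in that place, stays within the scatter of compound 1, though this one step says nothing about other cores. Nothing measured here speaks to what lies behind this step.

From the compounds shown here alone, it remains open whether a longer chain such as n-butyl, or a chain ending in an amine or a carboxylic acid, on the same nitrogen would shift the number in this assay beyond the scatter. Also open, going by these compounds, is whether hydrogen in place of cyclopropyl would read the same on the core of compound 2, and how the same change would behave on a core that gives a higher number in this assay.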